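Pentafluorophenylsulfonamide hydroxamates: benzyl substituent step to trifluoromethyl

The source may report more compounds than this note shows. Statements on the series, on what has been measured and on what is new or still open speak of the compounds shown alone.

Measured so far:
compound 1, `O=C(NO)c1ccc(CN(Cc2ccccc2)S(=O)(=O)c2c(F)c(F)c(F)c(F)c2F)cc1`: in an assay on isolated protein for inhibition of histone deacetylase 11 (Homo sapiens), read by mobility shift assay (on this read-out higher numbers stand for weaker inhibition and lower numbers for stronger inhibition), compound 1 gives 122 nM
compound 2, `O=C(NO)c1ccc(CN(Cc2ccc(F)cc2)S(=O)(=O)c2c(F)c(F)c(F)c(F)c2F)cc1`: in this assay compound 2 gives 787 nM

For the measured compounds named here, compound 2 stands at the higher of the two numbers; the single step at this position reads a 6.5-fold higher number from compound 1 to compound 2 (0.81 log units; beyond the scatter). Compound 3, `O=C(NO)c1ccc(CN(Cc2ccc(C(F)(F)F)cc2)S(=O)(=O)c2c(F)c(F)c(F)c(F)c2F)cc1`, differs from compound 2 by trifluoromethyl in place of fluoro on an aromatic carbon. Going by the values given here, no measured step covers trifluoromethyl in place of fluoro; only the step of a 6.5-fold higher number from compound 1 to compound 2 (0.81 log units; beyond the scatter) bears on this site, where the first substituent raised the number. A somewhat higher number is therefore expected, an estimated step of a 1.5-fold higher number from compound 2 to compound 3 (0.18 log units; within the scatter) in this assay. Compound 3 is estimated at 1200 nM, within 300 nM to 5000 nM.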

Compound 3, half-maximal inhibitory concentration: > 1000 nM
Compound 3 ended at the assay's limit; the forecaster's own chance of this, stated with the estimate: 5%; the middle value lies beyond the limit too.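

In this assay compound 3 gives > 1000 nM, which is a limit of the assay and not a number. Trifluoromethyl at this place also stands clearly apart from hydrogen, reading an at least 8.1-fold higher number from compound 1 to compound 3 (0.91 log units; beyond the scatter), so both substituents shown carry higher numbers than the unsubstituted compound 1. Against fluoro the reading is an at least 1.2-fold higher number from compound 2 to compound 3 (0.10 log units; that floor lies within the scatter), and trifluoromethyl and fluoro stay unseparated because compound 3 sits at the limit: the limit of > 1000 nM in this assay, at which 1 of the 3 values shown sits.

Open, as far as these compounds go, is whether any group at this place returns the number towards that of compound 1, for instance an amine or a carboxylic acid.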